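Replacing bromo with trifluoromethyl in a cytotoxicity series

The source may report more compounds than this note shows. Statements on the series, on what has been measured and on what is new or still open speak of the compounds shown alone.

- Compound 1 `CN1C/C(=C\c2ccc(F)cc2)C(=O)/C(=C/c2ccc(C#N)cc2)C1`: 20900 nM
- Compound 2 `CN1C/C(=C\c2ccc(Cl)cc2)C(=O)/C(=C/c2ccc(C#N)cc2)C1`: 16200 nM
- Compound 3 `CN1C/C(=C\c2ccc(Br)cc2)C(=O)/C(=C/c2ccc(C#N)cc2)C1`: 10500 nM

These values come from an ADME assay on L02 cells (Homo sapiens) for cytotoxicity, read by MTT assay, with a stated time of 24 h; on this read-out lower numbers stand for stronger inhibition and higher numbers for weaker inhibition. Compound 3 cannot be separated from the other two compounds on these numbers. The gaps are a 1.5-fold lower number from compound 2 to compound 3 (0.19 log units; within the scatter) and a 2.0-fold lower number from compound 1 to compound 3 (0.30 log units; within the scatter), and both lie within the scatter, as does a 1.3-fold lower number from compound 1 to compound 2 (0.11 log units; within the scatter).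

The next compound is compound 4 `CN1C/C(=C\c2ccc(C#N)cc2)C(=O)/C(=C/c2ccc(C(F)(F)F)cc2)C1`. Its change from compound 3 is trifluoromethyl in place of bromo on an aromatic carbon. For the measured compounds named here, no measured compound carries trifluoromethyl, so the three halogen swaps are the only guide. None of them went beyond the scatter, so no step beyond the scatter is expected in this assay, and no firm direction can be called. The estimated step is a 1.3-fold higher number from compound 3 to compound 4 (0.11 log units; within the scatter), which is expected to stay within the scatter. For compound 4 the expected value is 13500 nM, with an estimated range from 6500 nM to 27000 nM.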

Compound 4, half-maximal inhibitory concentration: 17200 nM
Beside the measured number, compound 4's estimate is 1.3-fold (0.11 log units) below it; the measured number falls inside the stated range.
By their numbers in this assay, from the lowest: compounds 3, 2, 4 and 1 (each within the scatter of the next).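

In this assay, for the compounds shown here, the first group that is not a single halogen atom still leaves the number within the scatter, whichever halogen it is set against: bromo (a 1.6-fold higher number from compound 3 to compound 4 (0.21 log units; within the scatter)), chloro (a 1.1-fold higher number from compound 2 to compound 4 (0.03 log units; within the scatter)) and fluoro (a 1.2-fold lower number from compound 1 to compound 4 (0.08 log units; within the scatter)). So this place on the aromatic ring, para to a large group, accepts trifluoromethyl as well as the three halogens without a step that can be told from repeat-measurement noise, and no order among the four compounds can be drawn. Nothing shown explains why these numbers stay so close.

From the compounds shown here alone, whether a group of a different kind, such as an amine or a carboxylic acid, would stay within the scatter at this place remains open. So does whether any group here can move the number beyond it.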